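Swapping a pyrrole for a furan in a weak growth inhibitor

A few compounds are considered here, and "the series" means these few. Any claim that something is new, unique, unknown or untested is made for them only; others in the source may bear on it.

Of the compounds shown here, three have been tested in a functional assay on SMA cells (Homo sapiens) for inhibition, read by MTT assay, with a stated time of 72 h; on this read-out higher numbers stand for weaker inhibition of growth and lower numbers for stronger inhibition of growth. Compound 1, `N#C/C(=C\c1ccc(Cl)cc1)C(=O)c1ccc[nH]1`, gives 38000 nM in this assay. Compound 2, `COc1ccc(CNC(=O)/C(C#N)=C/c2ccc[nH]2)cc1`, gives only a limit, > 50000 nM, in this assay. Compound 3, `N#C/C(=C\c1ccc[nH]1)C(=O)NCc1ccc(Cl)c(Cl)c1`, likewise gives only a limit, > 50000 nM. So compound 2 stands at the limit of > 50000 nM in this assay, at which 2 of the 3 values shown sit, and no number for it is known, only that it falls beyond that limit.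

Compound 4, `COc1ccc(CNC(=O)/C(C#N)=C/c2ccco2)cc1`, differs from compound 2 in one place: furan-2-yl in place of 1H-pyrrol-2-yl on a double-bonded chain carbon bound to a double-bonded chain carbon. Among the measured compounds shown here, with no measured pair that makes this exact swap, there is no step to lean on, and the starting point is itself a limit rather than a number.

The expectation is therefore modest: compound 4 is expected to remain a weak inhibitor of growth, with the step from compound 2 to compound 4 estimated at a step that the limit leaves unreadable from compound 2 to compound 4, which is not clearly beyond the scatter in either direction. For compound 4 in this assay the estimate is 60000 nM, in a range from 25000 nM to 150000 nM, and it is quite likely that this measurement too will come back only as a limit.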

Compound 4, concentration for 50% growth inhibition: 33000 nM
Beside the measured number, compound 4's estimate is 1.8-fold (0.26 log units) above it; the measured number falls inside the stated range.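

In this assay, putting furan-2-yl in place of 1H-pyrrol-2-yl on a double-bonded chain carbon bound to a double-bonded chain carbon gives an at least 1.5-fold lower number from compound 2 to compound 4 (0.18 log units; that floor lies within the scatter), and compound 4 reads 33000 nM, so this swap now has a measured number on one side of it. The change removes the hydrogen-bond donor counted for 1H-pyrrol-2-yl and brings in the hydrogen-bond acceptor counted for furan-2-yl, and compound 4 still returns a number rather than a limit, which shows that the donor on this ring is not needed to obtain one. The true size of the step stays unknown, and the printed figure is only a floor, because compound 2 gives a limit and not a number: the limit of > 50000 nM in this assay, at which 2 of the 4 values shown sit.

On these data alone, this swap is seen only once, on the core of compound 2, and whether it would give a similar result on the core of compound 3 remains open. Also open, as far as these compounds go, is what a thiophene ring, with sulfur in place of the furan oxygen, would give at this same place.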